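A few compounds are considered here, and "the series" means these few. Any claim that something is new, unique, unknown or untested is made for them only; others in the source may bear on it.

In a functional assay on KB cells (Homo sapiens) for inhibition, with a stated time of 72 h (a higher number here means a weaker inhibitor, a lower number a stronger inhibitor), compound 1 `COc1ccc(S(=O)(=O)N2CCc3cccc(-c4ccco4)c32)cc1` gives 82 nM, compound 2 `COc1ccc(S(=O)(=O)N2CCc3cccc(-c4ccc(N(C)C)cc4)c32)cc1` gives 539 nM and compound 3 `COc1ccc(S(=O)(=O)N2CCc3cccc(-c4ccncc4)c32)cc1` gives 96 nM. That leaves compound 3 level with compound 1 and clearly under compound 2: the gaps are a 1.2-fold higher number from compound 1 to compound 3 (0.07 log units; within the scatter) and a 5.6-fold lower number from compound 2 to compound 3 (0.75 log units; beyond the scatter). Compound 4 `COc1ccc(S(=O)(=O)N2CCc3cccc(-c4cccs4)c32)cc1` alters one group on the shared core: thiophen-2-yl in place of pyridin-4-yl on an aromatic carbon. In words, thiophen-2-yl replaces pyridin-4-yl on an aromatic carbon. Compound 1 is the closest guide, as its furan-2-yl is also a five-membered aromatic ring. Going by the values given here, the one step beyond the scatter came with 4-(dimethylamino)phenyl, a 6.6-fold higher number from compound 1 to compound 2 (0.82 log units; beyond the scatter). No step beyond the scatter is therefore expected in this assay, and the estimated change is a 1.1-fold lower number from compound 3 to compound 4 (0.05 log units; within the scatter). For compound 4 the expected value is 85 nM, with an estimated range of 35 nM to 210 nM.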

Compound 4, half-maximal inhibitory concentration: 215 nM
For compound 4 the middle estimate is 2.5-fold (0.40 log units) below the measured one; the measured number lies above the stated range.
By their numbers in this assay, from the lowest: compounds 1 and 3 (each within the scatter of the next); then compound 4; then compound 2.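

In this assay, thiophen-2-yl and furan-2-yl are both five-membered aromatic rings with one hetero atom, yet swapping one for the other gives a 2.6-fold higher number from compound 1 to compound 4 (0.42 log units; beyond the scatter), so sharing that ring size does not guarantee a matching number at this position. Thiophen-2-yl also falls behind pyridin-4-yl, with a 2.2-fold higher number from compound 3 to compound 4 (0.35 log units; beyond the scatter), while it stays ahead of 4-(dimethylamino)phenyl, with a 2.5-fold lower number from compound 2 to compound 4 (0.40 log units; beyond the scatter). No measurement offered here explains these differences. Still open, on these data alone, is how a piperidine ring or a carboxylic acid would fare at this position, and whether thiophen-3-yl would match thiophen-2-yl.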